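Swapping 2,3-dichlorophenyl for 4-cyanophenyl on a shared core

The source may hold more compounds than are shown below. What is called first, only, known or untested is meant among the compounds shown, and "the series" means these compounds.

- Compound 1 `CNC(=O)c1cc(Oc2ccc(C3=NN(C(N)=S)C(c4ccc(F)cc4)C3)cc2)ccn1`: > 50000 nM (a limit of the assay, not a number)
- Compound 2 `CNC(=O)c1cc(Oc2ccc(C3=NN(C(N)=S)C(c4cccc(Cl)c4Cl)C3)cc2)ccn1`: 1890 nM

Within the data shown here, in a functional assay on HepG2 cells (Homo sapiens) for cytotoxicity, read by MTT assay, with a stated time of 72 h (on this read-out lower numbers stand for stronger inhibition and higher numbers for weaker inhibition), compound 2 gives 1890 nM, the only exact number so far. Compound 3 `CNC(=O)c1cc(Oc2ccc(C3=NN(C(N)=S)C(c4ccc(C#N)cc4)C3)cc2)ccn1` has not yet been measured. It carries 4-cyanophenyl in place of 2,3-dichlorophenyl on a saturated ring carbon. Among the measured compounds shown here, only one measured step bears on this change, and it involves the same place on the shared core. That step is large: an at least 26-fold lower number from compound 1 to compound 2 (1.42 log units; beyond the scatter). Compound 3 returns to a phenyl group with one substituent, as in the 4-fluorophenyl of compound 1, although nitrile is not fluorine and a single step is thin evidence. A sizeable move to a higher number is therefore expected, estimated as an 11-fold higher number from compound 2 to compound 3 (1.02 log units; beyond the scatter). The assay may report only its limit. For compound 3 the estimated value is 20000 nM, with an expected range of 5000 nM to 50000 nM.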

Compound 3, half-maximal inhibitory concentration: > 50000 nM
Compound 3: no number, only a limit; the forecaster's own chance of this, stated with the estimate: 40%; at least 2.5-fold (0.39 log units) between middle value and limit.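

In this assay, 2,3-dichlorophenyl now stands out against two different replacements on the saturated ring carbon, not just one: changing it to 4-cyanophenyl gives an at least 26-fold higher number from compound 2 to compound 3 (1.42 log units; beyond the scatter). Compound 3 gives > 50000 nM, which is a limit of the assay and not a number. The step between compound 1 and compound 3 cannot be read, and nitrile and fluoro on the phenyl group cannot be ranked, because both compounds stop at the same point: the limit of > 50000 nM in this assay, at which 2 of the 3 values shown sit.

Still open, from the compounds shown here alone, is whether a phenyl group carrying a single chlorine, or a 2,3-dimethylphenyl group, would give an exact number at this position. Among these compounds, with compound 2 as the only exact value, it is also unclear whether the two chlorines or their placement on the ring matter more.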